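Replacing 4-chlorophenyl with 2-chloro-6-fluorophenyl in compound 3

The source may report more compounds than this note shows. Statements on the series, on what has been measured and on what is new or still open speak of the compounds shown alone.

Compound 1 `Cc1cc(=O)c2c(O)cc(O)c([C@H]3CCN(C)C[C@H]3OC(=O)c3ccco3)c2o1` gives 22% of inhibition
Compound 2 `Cc1cc(=O)c2c(O)c(CN3CCC(N4CCCCC4)CC3)c(O)c([C@H]3CCN(C)C[C@H]3O)c2o1` gives 34% of inhibition
Compound 3 `Cc1oc2c([C@H]3CCN(C)C[C@H]3O)c(O)cc(O)c2c(=O)c1C(O)c1ccc(Cl)cc1` gives 2% of inhibition

In a functional assay on HL-60 cells (Homo sapiens) for inhibition, read by MTT assay, with a stated time of 48 h, tested at 10 uM (on this read-out higher numbers stand for more inhibition of growth at the one concentration tested and lower numbers for less inhibition of growth), compound 3 stands lowest of the three, and its gaps to compound 1 and compound 2 both lie beyond the scatter. Compound 4 `Cc1oc2c([C@H]3CCN(C)C[C@H]3O)c(O)cc(O)c2c(=O)c1C(O)c1c(F)cccc1Cl` has no number yet. It differs from compound 3 by a single change (2-chloro-6-fluorophenyl in place of 4-chlorophenyl on a saturated chain carbon bound to an aromatic carbon and an oxygen on a saturated carbon), with 2-chloro-6-fluorophenyl in place of 4-chlorophenyl on a saturated chain carbon bound to an aromatic carbon and an oxygen on a saturated carbon.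

For the measured compounds named here, no two measured compounds differ in only one place, so the data offer no direct guide to this change. A small upward move in this assay is expected because compound 3 reads 2% and leaves little room to fall. The estimated step of a number 6 percentage points higher from compound 3 to compound 4 (within the scatter) is expected to stay within the scatter. For compound 4 the estimate is 8% with an expected range from 0% to 22% overall.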

Compound 4, percent growth inhibition at one concentration: 49%
For compound 4 the middle estimate is 41 percentage points below the measured one, and the stated range ends below it.
By their numbers in this assay, from the lowest: compound 3; then compound 1; then compound 2; then compound 4.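

In this assay, for the compounds shown here, replacing 4-chlorophenyl with 2-chloro-6-fluorophenyl gives a number 47 percentage points higher from compound 3 to compound 4 (beyond the scatter), the first reading of a single change in this set. It shows that, with the rest of the structure unchanged, growth inhibition responds strongly to the substitution on the phenyl group at this saturated chain carbon bound to an aromatic carbon and an oxygen on a saturated carbon. Nothing available bears on what lies behind this rise.

This one step cannot separate the entry of the fluorine from the change in where the chlorine sits, since both come with the same swap. It also leaves open how an unsubstituted phenyl, a pyridyl group or a phenyl carrying an amine would read at this carbon, and how the rise would appear at other concentrations.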